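The source may hold more compounds than are shown below. What is called first, only, known or untested is meant among the compounds shown, and "the series" means these compounds.

Compound 1 `O=C(/C=C/c1ccc2c(c1)B(O)OC2)c1cccnc1` and compound 2 `O=C(/C=C/c1ccc2c(c1)B(O)OC2)c1ccc([N+](=O)[O-])cc1` share the same core and differ only in the aromatic ring attached to the carbonyl carbon. In a functional assay on HCT-116 cells (Homo sapiens) for cytotoxicity, read by MTT assay, with a stated time of 48 h (on this read-out lower numbers stand for stronger inhibition and higher numbers for weaker inhibition), compound 1 gives 20500 nM, the highest of the two numbers recorded so far. Compound 2 gives 9100 nM in this assay, a lower number, and the gap between compound 2 and compound 1 lies beyond the usual scatter. For the measured compounds named here, no step between measured compounds that differ in a single place is available, so no measured change stands behind the move examined here.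

Compound 3 `Cc1cccc(C(=O)/C=C/c2ccc3c(c2)B(O)OC3)c1` differs from compound 1 in one place: 3-methylphenyl in place of pyridin-3-yl on a carbonyl carbon. Going by the values given here, only the pair of compound 1 and compound 2 shows how swapping this ring shifts this assay, and there the number fell modestly. Compound 3 is therefore expected to land close to compound 1, with a step of a 1.6-fold lower number from compound 1 to compound 3 (0.20 log units; within the scatter) that is small and, if anything, toward a lower number, not clearly beyond the scatter. The estimate for compound 3 in this assay is 13000 nM, within a range from 5000 nM to 32000 nM.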

Compound 3, half-maximal inhibitory concentration: 6700 nM
Compound 3: middle estimate off by 1.9-fold (0.29 log units), on the high side, within the range that was stated.
By their numbers in this assay, from the lowest: compounds 3 and 2 (each within the scatter of the next); then compound 1.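

In this assay, for the compounds shown here, putting 3-methylphenyl in place of pyridin-3-yl on a carbonyl carbon gives a 3.1-fold lower number from compound 1 to compound 3 (0.49 log units; beyond the scatter) and so provides the first single-change evidence that the ring at this place can move the number beyond the scatter. The ring nitrogen leaves and a methyl group enters in the same swap, so this step belongs to the two changes taken together, and it brings compound 3 within the scatter of compound 2, which carries a different ring at this place. Nothing measured here explains why the number moves.

A plain phenyl ring at this place would help separate the loss of the ring nitrogen from the gain of the methyl group, since it would differ from compound 3 only by that methyl group and from compound 1 only in the ring nitrogen. Going by these compounds, whether the number keeps falling or rises again with an amine or a carboxylic acid on this ring remains open, as does whether the same changes would act alike on a different core.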